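Swapping the ethoxy of compound 2

A few compounds are considered here, and "the series" means these few. Any claim that something is new, unique, unknown or untested is made for them only; others in the source may bear on it.

Compound 1 `COc1ccc(CSc2nnc(-c3cc(OC)c(OC)c(OC)c3)n2-c2ccc(OC)cc2)cc1`: 41100 nM
Compound 2 `CCOC(=O)CSc1nnc(-c2cc(OC)c(OC)c(OC)c2)n1-c1ccc(OC)cc1`: > 60000 nM
Compound 3 `COc1ccc(NC(=O)CSc2nnc(-c3cc(OC)c(OC)c(OC)c3)n2-c2ccc(OC)cc2)cc1`: not yet measured

Both measured compounds were tested in a functional assay on HepG2 cells (Homo sapiens) for inhibition, read by MTT assay, with a stated time of 48 h; on this read-out lower numbers stand for stronger inhibition and higher numbers for weaker inhibition. In this assay compound 2 gives > 60000 nM, which is a limit of the assay and not a number. Compound 2 therefore stands at the limit of > 60000 nM in this assay, at which 1 of the 2 values shown sits.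

Compound 3 keeps the shared core but carries (4-methoxyphenyl)amino in place of ethoxy on a carbonyl carbon.

Among the compounds with values here, only one measured step bears on this change: an at least 1.4-fold higher number from compound 1 to compound 2 (0.16 log units; that floor lies within the scatter). That step put ethoxycarbonyl in place of 4-methoxyphenyl on a saturated chain carbon bound to a sulfur, so it offers only a floor, not a firm size. Compound 3 regains a 4-methoxyphenyl group, which compound 1 also carries at 41100 nM, so a modest move towards a lower number is expected in this assay. Another limit reading would not be surprising.

The expected change is an at least 2.0-fold lower number from compound 2 to compound 3 (0.30 log units; that floor lies within the scatter). For compound 3 the estimated value is 30000 nM, with an expected range from 8000 nM to 80000 nM.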

Compound 3, half-maximal inhibitory concentration: > 60000 nM
Compound 3: only a limit was reported; the forecaster's own chance of this, stated with the estimate: 30%; at least 2.0-fold (0.30 log units) between middle value and limit.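

In this assay compound 3 gives > 60000 nM, which is a limit of the assay and not a number. Putting (4-methoxyphenyl)amino in place of ethoxy on a carbonyl carbon adds an aromatic ring and a hydrogen-bond donor, yet it still gives no measurable value, and the step between these two limits cannot be read: the limit of > 60000 nM in this assay, at which 2 of the 3 values shown sit.

Putting (4-methoxyphenyl)carbamoyl in place of 4-methoxyphenyl on a saturated chain carbon bound to a sulfur gives an at least 1.4-fold higher number from compound 1 to compound 3 (0.16 log units; that floor lies within the scatter), so this floor alone does not establish that the carbamoyl group makes the number higher.

The compounds shown leave open how far compound 2 and compound 3 really lie from each other, since neither has a measured number. They also leave open whether a different group on this carbonyl carbon, such as a free carboxylic acid or an amide with a longer chain, would give a measurable value in this assay.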